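Replacing morpholin-4-yl with 4-methoxyphenyl on compound 1

The source may hold more compounds than are shown below. What is called first, only, known or untested is meant among the compounds shown, and "the series" means these compounds.

compound 1 `O=C(COC(=O)/C=C/c1ccc(O)c(O)c1)NN1CCOCC1`: > 200000 nM
compound 2 `COc1cc(/C=C/C(=O)OCC(=O)Nc2ccc(Cl)cc2)cc(OC)c1OCc1ccc(Cl)c(Cl)c1`: 72400 nM

Both compounds were tested in a functional assay on LS174T cells (Homo sapiens) for cytotoxicity, read by MTT assay, with a stated time of 72 h; on this read-out lower numbers stand for stronger inhibition and higher numbers for weaker inhibition. Compound 1 shows > 200000 nM, which is a limit of the assay and not a number. It therefore has no measured strength to start from.

The next compound to follow is compound 3 `COc1ccc(NC(=O)COC(=O)/C=C/c2ccc(O)c(O)c2)cc1`. It differs from compound 1 by one change (4-methoxyphenyl in place of morpholin-4-yl on an amide-type nitrogen), with 4-methoxyphenyl in place of morpholin-4-yl on an amide-type nitrogen. Going by the values given here, no measured pair shows this change directly. Compound 2 also has a six-membered aromatic ring on an amide-type nitrogen and gives 72400 nM, but it differs from compound 1 elsewhere too. A modest move towards stronger inhibition is therefore expected, and the estimated change is an at least 2.2-fold lower number from compound 1 to compound 3 (0.34 log units; beyond the scatter). For compound 3 the estimated value is 90000 nM, with an expected range from 30000 nM to 200000 nM.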

Compound 3, half-maximal inhibitory concentration: 124000 nM
Compound 3: middle estimate off by 1.4-fold (0.14 log units), on the low side; low and high end bracket the measured number.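

In this assay compound 3 gives 124000 nM, so with 4-methoxyphenyl in place of morpholin-4-yl on the amide-type nitrogen, this core now has a measured number. Compound 1 gives > 200000 nM, which is a limit of the assay and not a number. The size of the change can therefore be stated only as a floor, an at least 1.6-fold lower number from compound 1 to compound 3 (0.20 log units; that floor lies within the scatter), so this single change is not shown to go beyond the usual scatter, and the result stays a floor because of this limit: the limit of > 200000 nM in this assay, at which 1 of the 3 values shown sits.

The compounds shown leave open whether the aromatic ring or its methoxy group accounts for the measured number. A plain phenyl group or a dimethylamino group on the same nitrogen would help to separate these contributions.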